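Methyl Placement on the Aromatic Ring of Compound 2

The compounds below may be only part of what the source reports. "The series", "measured", "known", "first", "only" and "open" are said of these compounds alone.

Compound 1 `COc1ccc(/C=N/Nc2nc(-c3ccc(Cl)cc3)cs2)cc1` and compound 2 `Cc1ccccc1/C=N/Nc1nc(-c2ccc(Cl)cc2)cs1` share one core and differ only in the aromatic group attached to the carbon with a double bond to nitrogen. In an in vitro assay on BTI-TN-5B1-4 cells for inhibition of Amine oxidase [flavin-containing] A (Homo sapiens), read by fluorescence, with a stated time of 15 min, tested at 100 uM (a lower number here means less inhibition, a higher number more inhibition at the concentration tested (going by the name of the read-out)), compound 1 gives 40%. In this assay compound 2 gives 40%, so compound 2 stands level with compound 1 at the digits shown, a gap that lies within the scatter of repeated measurements. Compound 3 `Cc1ccc(/C=N/Nc2nc(-c3ccc(Cl)cc3)cs2)cc1` has not yet been measured. It differs from compound 2 by 4-methylphenyl in place of 2-methylphenyl on a carbon with a double bond to nitrogen. For the measured compounds named here, no step between two measured compounds shows how such a change plays out, so the expectation rests on the two measured compounds alone, which give the same reading with different aromatic groups. From compound 2 to compound 3 a step no larger than the usual scatter is expected in this assay, in no particular direction. Compound 3 is therefore expected to give about 40% in this assay, within a range from 25% to 55%. That amounts to an expected step of no change at the digits printed from compound 2 to compound 3 (within the scatter).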

Compound 3, a percentage reported as inhibition, at one concentration (the size of the read-out at that concentration, not a potency): "not active" (no number reported)
Nothing numeric was reported for compound 3, so the estimate cannot be set against anything.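

In this assay, for the compounds shown here, compound 3 is reported only as "not active", without a number, so no step from compound 2 to compound 3 can be read. As far as these compounds go, how far 4-methylphenyl in place of 2-methylphenyl shifts the reading stays open, and no supporting evidence bears on this result.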